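The compounds below may be only part of what the source reports. "The series", "measured", "known", "first", "only" and "open" are said of these compounds alone.

Compound 1 `CC(=O)Nc1ccc(/C=N/Nc2nc(N)c3ncn([C@@H]4O[C@H](CO)[C@@H](O)[C@H]4O)c3n2)cc1` gives > 10000 nM in an assay on CHO-K1 cells for displacement of a labelled ligand from adenosine receptor A1 (Homo sapiens), read by scintillation counting, with a stated time of 60 min; a higher number here means a weaker inhibitor, a lower number a stronger inhibitor; this is a limit of the assay, not a number.
Compound 2 `COc1cc(/C=N/Nc2nc(N)c3ncn([C@@H]4O[C@H](CO)[C@@H](O)[C@H]4O)c3n2)cc(OC)c1OC` gives > 10000 nM in this assay, again a limit.
Compound 3 `CN(C)c1ccc(/C=N/Nc2nc(N)c3ncn([C@@H]4O[C@H](CO)[C@@H](O)[C@H]4O)c3n2)cc1` gives > 10000 nM in this assay, again a limit.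

Compound 1 therefore stands nowhere readable on the numbers shown: only a limit is known for it, and the other two values shown are limits as well (the limit of > 10000 nM in this assay, at which 3 of the 3 values shown sit). For the measured compounds named here, the one step between measured compounds that differ in a single place, a step that the two limits leave unreadable from compound 1 to compound 3, dimethylamino in place of acetamido on an aromatic carbon, cannot be read because both ends sit at the limit.

Compound 4 `CCCCc1nc(/C=N/Nc2nc(N)c3ncn([C@@H]4O[C@H](CO)[C@@H](O)[C@H]4O)c3n2)c(Cl)[nH]1` has not yet been measured in this assay. It differs from compound 1 by 2-butyl-5-chloro-1H-imidazol-4-yl in place of 4-acetamidophenyl on a carbon with a double bond to nitrogen. Going by the values given here, no measured step bears on this change with a readable size, so no direction beyond the scatter can be drawn from the measured pairs; the only evidence is that every value shown sits at the limit (the limit of > 10000 nM in this assay, at which 3 of the 3 values shown sit).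

Compound 4 is therefore expected to sit near the limit again, at an estimated 15000 nM with a range from 3000 nM to 60000 nM. The expected step that the limit leaves unreadable from compound 1 to compound 4 is an estimate only, not a measured change.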

Compound 4, inhibition constant: 12 nM
Compound 4: middle estimate off by 1300-fold (3.10 log units), on the high side, outside the stated range (below it).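

On a carbon with a double bond to nitrogen, 2-butyl-5-chloro-1H-imidazol-4-yl in place of 4-acetamidophenyl gives, in this assay, an at least 830-fold lower number from compound 1 to compound 4 (2.92 log units; beyond the scatter). The same group in place of 4-(dimethylamino)phenyl gives an at least 830-fold lower number from compound 3 to compound 4 (2.92 log units; beyond the scatter), so this place on the shared core can move the read-out far from the limit, and the two phenyl-bearing starting points lead to a readable result with the same entering group. Compound 4 is the only compound shown with a readable value, and the remaining steps among the earlier compounds cannot be read, leaving the series with a single measured point against a floor of limits: the limit of > 10000 nM in this assay, at which 3 of the 4 values shown sit.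

Which part of the entering group carries the step stays open: the butyl chain, the chlorine and the five-membered ring with its 2 hetero atoms all change together, and no compound shown holds one of them without the others. Also open, from the compounds shown here alone, is how a propyl chain in place of the butyl, a bromine in place of the chlorine, or a 4-butylphenyl group would read in this assay.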